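This account rests on a few compounds, and the source may have more. Where it says the series, first, only, none or still open, it means among the compounds named here.

Compound 1 `O=C(NCCNc1nccc(-c2c(-c3cccc(F)c3)nc3sccn23)n1)c1ccccc1` carries a benzoyl group on the amine nitrogen; in a functional assay on A-375 cells (Homo sapiens) for cytotoxicity, read by MTT assay (on this read-out higher numbers stand for weaker inhibition and lower numbers for stronger inhibition), compound 1 gives 5060 nM. Compound 2 `O=S(=O)(NCCNc1nccc(-c2c(-c3cccc(F)c3)nc3sccn23)n1)c1ccc(Br)cc1` carries (4-bromophenyl)sulfonyl in that place, and in this assay compound 2 gives 13500 nM. Among the compounds with values here, compound 2 therefore holds the highest of the two numbers recorded so far, its only neighbour being compound 1, separated by a 2.7-fold higher number from compound 1 to compound 2 (0.43 log units; beyond the scatter).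

Compound 3 `Cc1ccc(C(=O)NCCNc2nccc(-c3c(-c4cccc(F)c4)nc4sccn34)n2)cc1` differs from compound 2 by (4-methylphenyl)carbonyl in place of (4-bromophenyl)sulfonyl on an amine nitrogen. Within the data shown here, the one measured step that bears on this, a 2.7-fold higher number from compound 1 to compound 2 (0.43 log units; beyond the scatter), ran in the opposite sense, with sulfonyl replacing carbonyl; compound 3 undoes that change, so a step of about the same size back toward compound 1 is expected, downward in this assay. Among the measured compounds shown here, compound 3 differs from compound 1 only by (4-methylphenyl)carbonyl in place of benzoyl, for which no step is measured, so no added shift is assumed. Compound 3 is expected to give 5000 nM (range 2200 nM to 11000 nM), which means an estimated 2.7-fold lower number from compound 2 to compound 3 (0.43 log units; beyond the scatter).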

Compound 3, half-maximal inhibitory concentration: 5880 nM
Estimate against measurement, compound 3: 1.2-fold (0.07 log units) below; measured number inside the range.
By their numbers in this assay, from the lowest: compounds 1 and 3 (each within the scatter of the next); then compound 2.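

In this assay, the step of a 1.2-fold higher number from compound 1 to compound 3 (0.07 log units; within the scatter) shows that methyl in place of hydrogen on an aromatic carbon of the benzoyl group makes no readable difference, so the two carbonyl compounds stand level. The step of a 2.3-fold lower number from compound 2 to compound 3 (0.36 log units; beyond the scatter) then shows that a second carbonyl compound, not only compound 1, sits apart from the (4-bromophenyl)sulfonyl compound, and this holds for the three compounds shown. The data offer no explanation for either step.

From the compounds shown here alone, both steps involving compound 2 change the carbonyl to sulfonyl and the ring substituent together, so it remains open whether the sulfonyl or the bromine goes with its higher number. (4-Bromophenyl)carbonyl and phenylsulfonyl on the amine nitrogen would separate the two, while acetyl would test whether the aromatic ring is needed at all.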